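Swapping 3-fluorophenyl for 2,3-dimethylphenyl in compound 4

This account rests on a few compounds, and the source may have more. Where it says the series, first, only, none or still open, it means among the compounds named here.

In a functional assay on A549 cells (Homo sapiens) for antiproliferative activity, read by MTT assay, with a stated time of 72 h (on this read-out lower numbers stand for stronger inhibition and higher numbers for weaker inhibition), compound 3 (`COc1cc(-n2cnc3ccc(-c4cccc(F)c4)cc32)cc(OC)c1OC`) gives 5270 nM and compound 2 (`COc1cc(-n2cnc3ccc(-c4ccccc4)cc32)cc(OC)c1OC`) gives 3060 nM, which amounts to a 1.7-fold higher number from compound 2 to compound 3 (0.24 log units; within the scatter). Compound 1 (`COc1cc(-n2cnc3ccc(-c4ccc(C)cc4F)cc32)cc(OC)c1OC`) is reported only as a limit, > 10000 nM. Compound 4 (`COc1cc(-n2cnc3ccc(-c4cccc(C)c4C)cc32)cc(OC)c1OC`) places 2,3-dimethylphenyl in place of 3-fluorophenyl on an aromatic carbon of the shared core: 2,3-dimethylphenyl in place of 3-fluorophenyl on an aromatic carbon. The closest guide is compound 1, which also bears two groups on its phenyl; replacing its 2-fluoro-4-methylphenyl gave an at least 3.2-fold lower number from compound 1 to compound 2 (0.51 log units; beyond the scatter) and an at least 1.8-fold lower number from compound 1 to compound 3 (0.27 log units; that floor lies within the scatter). A small move towards a higher number is therefore expected, estimated as a 1.5-fold higher number from compound 3 to compound 4 (0.18 log units; within the scatter). Compound 4 is estimated at 8000 nM, with an expected range of 3500 nM to 18000 nM.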

Compound 4, half-maximal inhibitory concentration: 9250 nM
Compound 4: the middle estimate sits 1.2-fold (0.06 log units) below what was measured; the range from low to high includes it.
By their numbers in this assay, from the lowest: compounds 2, 3 and 4 (each within the scatter of the next, the first and the last beyond it). At a limit, above all of these: compound 1.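

In this assay, among these compounds, replacing phenyl with 2,3-dimethylphenyl gives a 3.0-fold higher number from compound 2 to compound 4 (0.48 log units; beyond the scatter), the first fully measured step at this position that clears the scatter, while the change from 3-fluorophenyl gives only a 1.8-fold higher number from compound 3 to compound 4 (0.24 log units; within the scatter). A phenyl carrying two groups is thus now tied to a higher number by an exact value. Compound 1 stands only at a limit: the limit of > 10000 nM in this assay, at which 1 of the 4 values shown sits. Taken against that limit, the step is an at least 1.0-fold lower number from compound 1 to compound 4 (0.03 log units; that floor lies within the scatter), and it cannot be read as a difference.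

Whether either methyl alone accounts for the step remains open. So does whether an amine or a carboxylic acid on this phenyl would lower the number below that of compound 2.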